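The source may report more compounds than this note shows. Statements on the series, on what has been measured and on what is new or still open speak of the compounds shown alone.

Compound 1 `Oc1ccc(Cn2cccn2)c2cccnc12`, compound 2 `CC(=O)Oc1ccc(Cn2ccnc2)c2cccnc12`, compound 3 `CC(=O)Oc1ccc(Cn2cnc(F)c2)c2cccnc12` and compound 4 `O=C(Oc1ccc(Cn2ccnc2)c2cccnc12)c1ccccc1` share one core and differ in the group attached to its oxygen and in the five-membered ring on the linking carbon. In a functional assay on MM1.S cells (Homo sapiens) for antiproliferative activity, read by luminescence, with a stated time of 72 h (a higher number here means a weaker inhibitor, a lower number a stronger inhibitor), compound 1 gives 700 nM and compound 3 gives 1100 nM; those two values lie within the usual scatter of each other. From the compounds shown here alone, for compound 2 the entry in this assay reads "not determined" (no result reported), so its own standing is unknown. The step from compound 2 to compound 4 is phenyl in place of methyl on a carbonyl carbon. Going by the values given here, with no measured pair showing what such a change does, the expectation is a step within the scatter, in no clear direction. Compound 4 is therefore estimated at 1000 nM, somewhere between 300 nM and 4000 nM.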

Compound 4, half-maximal inhibitory concentration: 2900 nM
Compound 4: the middle estimate sits 2.9-fold (0.46 log units) below what was measured; measured number inside the range.
By their numbers in this assay, from the lowest: compounds 1 and 3 (each within the scatter of the next); then compound 4.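

Compound 4 differs in one place only from compound 2, which has no single number in this assay, so no step can be read for compound 4. The compounds shown leave open what the change from acetyl to benzoyl does to activity, and no evidence on hand bears on the result.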